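Second Fluorine on a Fluorinated Acrylamide Core

This account rests on a few compounds, and the source may have more. Where it says the series, first, only, none or still open, it means among the compounds named here.

Measured compounds:
compound 1 `NC(=O)/C=C1\CCc2c(F)cccc21`: 34%
compound 2 `NC(=O)/C=C1\CCc2cc(F)cc(F)c21`: 55%
compound 3 `NC(=O)/C=C1\CCc2cc(F)ccc21`: 42%

Of the compounds shown here, three have been tested in a functional assay on the whole organism with Rattus norvegicus as the target, at a dose of 20 mg/kg by the oral route; a lower number here means less inhibition, a higher number more inhibition at the dose given (going by the name of the read-out). Compound 1 gives 34% in this assay, and compound 3 gives 42%; the gap between these two lies within the scatter of the measurement, so no order is drawn between them. Compound 1 and compound 3 are built from the same atoms joined differently, and the difference between the two cores is not broken down here. From compound 3 to compound 2 the change is fluoro in place of hydrogen on an aromatic carbon, and this step gives a number 13 percentage points higher from compound 3 to compound 2 (beyond the scatter), a modest rise beyond the scatter.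

Compound 4 `NC(=O)/C=C1\CCc2c(F)ccc(F)c21` has not yet been measured. It differs from compound 1 by fluoro in place of hydrogen on an aromatic carbon. For the measured compounds named here, this is the same kind of change as the one from compound 3 to compound 2, not the same: in compound 2 the entering fluoro sits meta to a fluoro group, whereas in compound 4 it sits para to a fluoro group. Going by the values given here, compound 4 is expected to give 47%, within 30% to 65%, because a number 13 percentage points higher from compound 3 to compound 2 (beyond the scatter) is the only measured example of this kind of change. The expected step is a number 13 percentage points higher from compound 1 to compound 4 (beyond the scatter). The range is kept wide because the change in compound 4 is only the same kind, not identical.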

Compound 4, a percentage reported as inhibition, in the whole organism at one dose (the size of the read-out at that dose, not a potency): 67%
Compound 4: the middle estimate sits 20 percentage points below what was measured; measured number above the stated range.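

In this assay, a second fluoro raises the number on both cores, and the new step is a number 33 percentage points higher from compound 1 to compound 4 (beyond the scatter), so the direction of this change held when it was carried from the core of compound 3 to the core of compound 1. The size of the step did not carry over, and the two steps stand clearly apart: the same change on two cores in this assay, a number 13 percentage points higher (beyond the scatter) from compound 3 to compound 2 and a number 33 percentage points higher (beyond the scatter) from compound 1 to compound 4, 20 percentage points apart, beyond the scatter of two such steps The two pairs differ both in the core and in where the fluoro enters, para to a fluoro group in compound 4, so they cannot show which of these sets the size of the step, and two steps give no rule for other cores.

All four compounds carry only fluoro on the aromatic ring, which leaves open how a chloro, methoxy or trifluoromethyl group at these places would read in this assay. Also open, going by these compounds, is what a carboxylic acid or a nitrile in place of the amide would do on either core.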